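A few compounds are considered here, and "the series" means these few. Any claim that something is new, unique, unknown or untested is made for them only; others in the source may bear on it.

This study concerns a small set of urea-linked compounds examined in a functional assay on CHO cells for agonist activity at sphingosine 1-phosphate receptor 2 (Homo sapiens), read by fluorescence and calcium flux, with a stated time of 3 min; on this read-out higher numbers stand for weaker inhibition and lower numbers for stronger inhibition. Compound 1, `Cc1cc(NNC(=O)Nc2cc(Cl)nc(Cl)c2)ncc1N(C)C`, gave in this assay only a limit, > 23000 nM. Compound 2, `Cc1cc(C#N)nc(NNC(=O)Nc2cc(Cl)nc(Cl)c2)c1`, likewise reached in this assay only a limit, > 23000 nM. Compound 2 thus stands exactly where compound 1 stands: the limit of > 23000 nM in this assay, at which 2 of the 2 values shown sit, sums up the whole picture, every shown value resting at the same limit and no measured step running between any two compounds.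

Compound 3, `Cc1cc(NNC(=O)Nc2cc(Cl)nc(Cl)c2)nc(C(=O)N(C)C)c1`, is the next compound and has not yet been measured in this assay. Its change from compound 2 is dimethylcarbamoyl in place of cyano on an aromatic carbon. Among the measured compounds shown here, no measured step in this assay tells how much such a swap matters on the shared core. With both measured compounds at the limit, there is no direction to lean toward. The step that the limit leaves unreadable from compound 2 to compound 3 is expected to stay within the scatter. Compound 3 is therefore estimated at 40000 nM, with a range from 8000 nM to 200000 nM.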

Compound 3, half-maximal inhibitory concentration: > 23000 nM
Compound 3: a limit, no number (the forecaster's own chance of this, stated with the estimate: 80%); the middle value lies beyond the limit too.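

In this assay compound 3 gives > 23000 nM as a limit of the assay and not a number. Among the compounds shown here, no step from compound 2 to compound 3 can therefore be read: the limit of > 23000 nM in this assay, at which 3 of the 3 values shown sit. The compounds shown leave open whether dimethylcarbamoyl in place of cyano on an aromatic carbon matters at all, and whether any change to the shared core gives a readable number in this assay.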